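Cytotoxicity notes: from compound 2 to compound 3

A few compounds are considered here, and "the series" means these few. Any claim that something is new, unique, unknown or untested is made for them only; others in the source may bear on it.

Two compounds of the series have so far been run in an ADME assay on BJ cells (Homo sapiens) for cytotoxicity, with a stated time of 72 h; on this read-out lower numbers stand for an effect already at smaller amounts and higher numbers for an effect only at larger amounts of compound. Compound 1 `COc1cc2nc(N)nc(-n3nc(-c4ccccn4)nc3N)c2cc1OC` reaches only the assay limit, > 27000 nM. Compound 2 `COc1cc2ncnc(-n3nc(-c4ccccn4)nc3N)c2cc1OCc1ccccc1` likewise reaches only the assay limit, > 27000 nM. Both values thus sit at the limit of > 27000 nM in this assay, at which 2 of the 2 values shown sit, so the numbers shown allow no ordering of compound 1 against compound 2, and compound 2 stands at the limit alongside compound 1.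

Compound 3 `COc1cc2ncnc(-n3nc(-c4ccccn4)nc3N)c2cc1OCCCNC(=O)OCC(F)(F)F` has not yet been measured in this assay. It differs from compound 2 in one place: 2-(((2,2,2-trifluoroethoxy)carbonyl)amino)ethyl in place of phenyl on a saturated chain carbon bound to an oxygen on an aromatic ring. No measured pair in the series covers a change of this kind, and nothing among the shown values speaks for a shift beyond the usual scatter in this assay. The step is expected to amount to a step that the limit leaves unreadable from compound 2 to compound 3, that is, none beyond the scatter. Compound 3 is therefore expected near the limit, at 30000 nM, within 15000 nM to 60000 nM.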

Compound 3, half-maximal effective concentration: > 11000 nM
Compound 3 was reported as a limit; the forecaster's own chance of this, stated with the estimate: 85%; the middle value is on the limit's open side.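

For the compounds shown here, compound 2 and compound 3 both stand only as limits in this assay, so no step between them can be read. The compounds shown leave open whether 2-(((2,2,2-trifluoroethoxy)carbonyl)amino)ethyl in place of phenyl changes the read-out in this assay at all.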